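From 2,4-dimethoxyphenyl to 3-chlorobenzyl in the series

This account rests on a few compounds, and the source may have more. Where it says the series, first, only, none or still open, it means among the compounds named here.

In a functional assay on EOL1 cells (Homo sapiens) for inhibition, read by fluorescence, with a stated time of 72 h (a higher number here means a weaker inhibitor of growth, a lower number a stronger inhibitor of growth), compound 1 (`COc1ccc(Nc2nc(N[C@H]3CC[C@H](N)CC3)nc3c2ncn3CCC(C)C)c(OC)c1`) gives 630 nM, the higher of the two measured values. Compound 2 (`CC(C)=CCn1cnc2c(Nc3cccc(Cl)c3)nc(N[C@H]3CC[C@H](N)CC3)nc21`) gives 80 nM, lower by more than the scatter. Compound 3 (`CC(C)CCn1cnc2c(NCc3cccc(Cl)c3)nc(N[C@H]3CC[C@H](N)CC3)nc21`) places 3-chlorobenzyl in place of 2,4-dimethoxyphenyl on a nitrogen on an aromatic ring. Within the data shown here, no single-change step supports this swap, so the expectation rests only on compound 2 at 80 nM, which also carries chlorine. The expected change toward stronger growth inhibition is a 3.2-fold lower number from compound 1 to compound 3 (0.50 log units; beyond the scatter). For compound 3 the estimated value is 200 nM, with an expected range of 60 nM to 700 nM.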

Compound 3, concentration for 50% growth inhibition: 1330 nM
For compound 3 the middle estimate is 6.7-fold (0.82 log units) below the measured one; measured number outside the range, above it.
By their numbers in this assay, from the lowest: compound 2; then compound 1; then compound 3.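

At the nitrogen on an aromatic ring, the series now has a first single-change reading: in this assay the swap to 3-chlorobenzyl gives a 2.1-fold higher number from compound 1 to compound 3 (0.32 log units; beyond the scatter) and so a modest loss of growth inhibition. The step changes the ring substituents and adds the benzyl carbon together, so the shift cannot be assigned to either alone. Nothing available here accounts for the shift.

From the compounds shown here alone, whether the benzyl carbon or the ring substituents drive this step stays open. An unsubstituted benzyl or a 2,4-dimethoxybenzyl on this nitrogen would separate the two.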